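Three amides at the assay limit, a fourth awaited

This account rests on a few compounds, and the source may have more. Where it says the series, first, only, none or still open, it means among the compounds named here.

Compound 1 `COc1ccc2c(=O)c(/C=C/C(=O)Nc3ccc(Cl)cc3)coc2c1` carries a 4-chlorophenyl on its amide-type nitrogen. In a functional assay on L02 cells (Homo sapiens) for inhibition, read by MTT assay, with a stated time of 48 h (a lower number here means a stronger inhibitor, a higher number a weaker inhibitor), compound 1 gives > 200000 nM, which is a limit of the assay and not a number. Two related compounds give the same picture. Compound 2 `O=C(/C=C/c1coc2cc(O)ccc2c1=O)NCc1ccccc1` gives in this assay > 200000 nM, again a limit. Compound 3 `O=C(/C=C/c1coc2cc(O)ccc2c1=O)Nc1ccccc1`, with phenyl in place of benzyl on that nitrogen, gives in this assay > 200000 nM, also a limit. The step that the two limits leave unreadable from compound 2 to compound 3 therefore cannot be read. Because (the limit of > 200000 nM in this assay, at which 3 of the 3 values shown sit), compound 1 stands exactly where compounds 2 and 3 stand, with no value that can be ranked against theirs.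

Compound 4 `COc1ccc2c(=O)c(/C=C/C(=O)Nc3ccccc3C)coc2c1` differs from compound 1 by 2-methylphenyl in place of 4-chlorophenyl on an amide-type nitrogen. Among the compounds with values here, no measured step in this set touches a 2-methylphenyl or a 4-chlorophenyl group, and the one step that alters the group on the amide-type nitrogen is unreadable. Within the data shown here, the only guide is that every value so far sits at the limit. Compound 4 is therefore expected to stay at the limit as well, estimated at 300000 nM within 150000 nM to 1000000 nM. The step that the limit leaves unreadable from compound 1 to compound 4 is accordingly expected to be none beyond the scatter.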

Compound 4, half-maximal inhibitory concentration: > 200000 nM
Compound 4: a limit, no number; the forecaster's own chance of this, stated with the estimate: 85%; the middle value is on the limit's open side.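

In this assay compound 4 gives > 200000 nM, a limit of the assay and not a number. No step can be read from compound 1 to compound 4, because neither compound has a number to compare: the limit of > 200000 nM in this assay, at which 4 of the 4 values shown sit.

The compounds shown leave open how the four rank against one another and whether any group on the amide-type nitrogen gives a readable value in this assay.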